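This account rests on a few compounds, and the source may have more. Where it says the series, first, only, none or still open, it means among the compounds named here.

Compound 1 `Oc1cccc(-c2cc(-c3cccc(C(F)(F)F)c3)cc(-c3ccccc3O)n2)c1` gives 13000 nM in a functional assay on DU-145 cells (Homo sapiens) for inhibition; a lower number here means a stronger inhibitor, a higher number a weaker inhibitor. For compound 2 `Oc1cccc(-c2cc(-c3ccc(C(F)(F)F)cc3)cc(-c3ccccc3O)n2)c1` this assay reports only a limit, > 50000 nM. For compound 3 `Oc1cccc(-c2cc(-c3cccc(C(F)(F)F)c3)cc(-c3cccc(O)c3)n2)c1` this assay likewise reports only a limit, > 50000 nM. The change 4-(trifluoromethyl)phenyl in place of 3-(trifluoromethyl)phenyl on an aromatic carbon produced an at least 3.8-fold higher number from compound 1 to compound 2 (0.58 log units; beyond the scatter), a step whose size is bounded by the limit of > 50000 nM in this assay, at which 2 of the 3 values shown sit. Compound 4 `Oc1cccc(-c2cc(-c3ccc(C(F)(F)F)cc3)cc(-c3cccc(O)c3)n2)c1` is not yet measured. The cores of compound 3 and compound 1 differ as 3-hydroxyphenyl in place of 2-hydroxyphenyl on an aromatic carbon, which gave an at least 3.8-fold higher number from compound 1 to compound 3 (0.58 log units; beyond the scatter). The change from compound 3 to compound 4 is 4-(trifluoromethyl)phenyl in place of 3-(trifluoromethyl)phenyl on an aromatic carbon, the same kind of change as that from compound 1 to compound 2, though here the place is meta to two 3-hydroxyphenyl groups rather than meta to a 2-hydroxyphenyl group and a 3-hydroxyphenyl group. Since compound 3 already sits at the limit of > 50000 nM in this assay, at which 2 of the 3 values shown sit, the expected step is a step that the limit leaves unreadable from compound 3 to compound 4. Compound 4 is therefore estimated at 100000 nM, between 40000 nM and 400000 nM.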

Compound 4, half-maximal inhibitory concentration: 33500 nM
The estimate for compound 4 lay 3.0-fold (0.47 log units) above the measured number; measured number outside the range, below it.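

In this assay, 4-(trifluoromethyl)phenyl in place of 3-(trifluoromethyl)phenyl gave an at least 1.4-fold lower number from compound 3 to compound 4 (0.17 log units; that floor lies within the scatter), so this change did not carry over with the same result from the core of compound 1: the same change on two cores in this assay, an at least 3.8-fold higher number (0.58 log units; beyond the scatter) from compound 1 to compound 2 and an at least 1.4-fold lower number (0.17 log units; that floor lies within the scatter) from compound 3 to compound 4, at least 5.7-fold (0.75 log units) apart, beyond the scatter of two such steps

Likewise, 3-hydroxyphenyl in place of 2-hydroxyphenyl gave an at least 1.4-fold lower number from compound 2 to compound 4 (0.17 log units; that floor lies within the scatter), and this change also gave a different result on the second core: the same change on two cores in this assay, an at least 3.8-fold higher number (0.58 log units; beyond the scatter) from compound 1 to compound 3 and an at least 1.4-fold lower number (0.17 log units; that floor lies within the scatter) from compound 2 to compound 4, at least 5.7-fold (0.75 log units) apart, beyond the scatter of two such steps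

What this does not show is the true size of either new step, since each starts from a limit and not from a number: the limit of > 50000 nM in this assay, at which 2 of the 4 values shown sit.

The compounds shown leave open how these two changes behave on any further core. They also leave open what happens when a nitrile or a methoxy group replaces the trifluoromethyl, or an amine replaces the hydroxyl.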